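The source may report more compounds than this note shows. Statements on the series, on what has been measured and on what is new or still open speak of the compounds shown alone.

Measured so far:
Compound 1 `CC(C)(C)C#Cc1cc(N(C(=O)[C@H]2CC[C@H](C)CC2)[C@H]2CC[C@](O)(CO[C@H]3CCOC3)CC2)c(C(=O)O)s1`: > 20000 nM (a limit, not a number)
Compound 2 `CC(C)(C)C#Cc1cc(N(C(=O)[C@H]2CC[C@H](C)CC2)[C@H]2CC[C@H](OC3CCOCC3)CC2)c(C(=O)O)s1`: > 20000 nM (a limit, not a number)
Compound 3 `CC1=CC[C@H](C(=O)N(c2cc(C#CC(C)(C)C)sc2C(=O)O)[C@H]2CC[C@](O)(CO[C@H]3CCOC3)CC2)CC1`: > 20000 nM (a limit, not a number)

In an ADME assay on MT4 cells (Homo sapiens) for cytotoxicity, with a stated time of 5 days (on this read-out lower numbers stand for higher toxicity in this test and higher numbers for lower toxicity in this test), compound 1 gives > 20000 nM. That is a limit and not a number. Compound 1 therefore has no exact place on the scale, and it shares its position with the other two: the record shows (the limit of > 20000 nM in this assay, at which 3 of the 3 values shown sit).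

The next compound to be tested is compound 4 `CC(C)(C)C#Cc1cc(N(C(=O)[C@H]2CC[C@H](C)CC2)[C@H]2CC[C@@](O)(CO[C@H]3CCOC3)CC2)c(C(=O)O)s1`, and it is compared here with compound 1: the two compounds have the same atoms and bonds and differ only in configuration as drawn: 3 of 5 stereo elements differ; a stereocentre at a saturated ring carbon is drawn R in compound 1 and S in compound 4; a stereocentre at a saturated ring carbon is drawn R in compound 1 and S in compound 4; a stereocentre at a saturated ring carbon is drawn s in compound 1 and r in compound 4. So only the three-dimensional arrangement changes, not the atoms or the bonds that join them.

Among the compounds with values here, the one measured step to consider is a step that the two limits leave unreadable from compound 1 to compound 3. It concerns 4-methylcyclohex-3-en-1-yl in place of 4-methylcyclohexyl on a carbonyl carbon, not a change of configuration, so it bears on compound 4 only loosely. Within the data shown here, no measured pair here tests configuration alone.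

Compound 1 is the closest comparison, and no step beyond the usual scatter is expected in either direction in this assay because of the limit of > 20000 nM in this assay, at which 3 of the 3 values shown sit. The expected change is a number no higher from compound 1 to compound 4 (the limit leaves the size open). The estimate for compound 4 is 20000 nM. The expected range for compound 4 runs from 12000 nM to 40000 nM, and a report as a limit is the likeliest outcome.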

Compound 4, half-maximal cytotoxic concentration: > 20000 nM
Compound 4 ended at the assay's limit; the forecaster's own chance of this, stated with the estimate: 85%; the middle value sits exactly at the limit.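

Compound 1 and compound 4 differ only in configuration as drawn, yet no step between them can be read in this assay because both results are limits and not numbers: the limit of > 20000 nM in this assay, at which 4 of the 4 values shown sit.

The compounds shown leave open whether configuration alone changes this read-out, and how far past the limit any of them lies.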